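A few compounds are considered here, and "the series" means these few. Any claim that something is new, unique, unknown or untested is made for them only; others in the source may bear on it.

In an assay on isolated protein for binding affinity to secreted frizzled-related protein 1 (Homo sapiens), read by fluorescence (on this read-out higher numbers stand for weaker inhibition and lower numbers for stronger inhibition), compound 1 `O=C(CN1CCNCC1)N1CCC(NS(=O)(=O)c2cc(S(=O)(=O)c3ccccc3)ccc2C(F)(F)F)CC1` gives 140 nM, and compound 2 `CC(C)(C)C(=O)N1CCC[C@H]1C(=O)N1CCC(NS(=O)(=O)c2cc(S(=O)(=O)c3ccccc3)ccc2C(F)(F)F)CC1` gives 40 nM. Of these two numbers, compound 2 holds the lower one, the step from compound 1 to compound 2 being a 3.5-fold lower number from compound 1 to compound 2 (0.54 log units; beyond the scatter). Compound 3 `CC(C)(C)CC(=O)N1CCC[C@H]1C(=O)N1CCC(NS(=O)(=O)c2cc(S(=O)(=O)c3ccccc3)ccc2C(F)(F)F)CC1` differs from compound 2 by neopentyl in place of tert-butyl on a carbonyl carbon. Among the measured compounds shown here, the single measured step, a 3.5-fold lower number from compound 1 to compound 2 (0.54 log units; beyond the scatter), exchanged the whole group on the carbonyl carbon and therefore does not directly bear on the exchange of tert-butyl for neopentyl; no measured pair separates these two groups. With nothing pointing either way, compound 3 is expected to remain close to compound 2 in this assay, the estimated step of a 1.1-fold higher number from compound 2 to compound 3 (0.05 log units; within the scatter) lying within the scatter. Compound 3 is thus estimated at 45 nM, with a range from 15 nM to 135 nM.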

Compound 3, half-maximal inhibitory concentration in the secreted frizzled-related protein 1 assay: 20 nM
Compound 3: middle estimate off by 2.3-fold (0.35 log units), on the high side, within the range that was stated.
By their numbers in the secreted frizzled-related protein 1 assay, from the lowest: compounds 3 and 2 (each within the scatter of the next); then compound 1.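

In the secreted frizzled-related protein 1 assay compound 2 gives 40 nM and compound 3 gives 20 nM with neopentyl in place of tert-butyl on the carbonyl carbon, which is a 2.0-fold lower number from compound 2 to compound 3 (0.30 log units; within the scatter) and so leaves the two groups indistinguishable, which shows that this position takes either one. The larger exchange, 1-(neopentylcarbonyl)pyrrolidin-2-yl in place of (piperazin-1-yl)methyl, gives a 7.0-fold lower number from compound 1 to compound 3 (0.85 log units; beyond the scatter) and remains beyond the scatter. In a physicochemical assay for solubility (a lower number here means a less soluble compound, a higher number a more soluble compound), compound 2 gives 50000 nM and compound 3 gives 25000 nM with the neopentyl for tert-butyl exchange, which is a 2.0-fold lower number from compound 2 to compound 3 (0.30 log units; within the scatter) and also stays within the scatter, and no evidence is available that would account for either reading.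

On these data alone, how a longer chain than neopentyl, a cyclohexyl group or an amine on this carbonyl carbon would read in the secreted frizzled-related protein 1 assay remains open. As far as these compounds go, it is also open how much of the difference between compound 1 and compound 3 belongs to the pyrrolidin-2-yl part and how much to the neopentylcarbonyl part.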